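The compounds below may be only part of what the source reports. "The series", "measured", "known", "first", "only" and "open" are said of these compounds alone.

Of the compounds shown here, three have been measured in a functional assay on A549 cells (Homo sapiens) for inhibition, read by MTT assay, with a stated time of 72 h; a lower number here means a stronger inhibitor, a higher number a weaker inhibitor. Compound 1 `Cn1ccc2c(Oc3ccc(NC(=O)c4cn(-c5ccc(Br)cc5)c5ccccc5c4=O)cc3F)ccnc21` gives 1390 nM in this assay. Compound 2 `Cn1ccc2c(Oc3ccc(NC(=O)c4cn(-c5ccc(Br)cc5F)c5ccccc5c4=O)cc3F)ccnc21`, which carries fluoro in place of hydrogen on an aromatic carbon, gives 1520 nM. That change made a 1.1-fold higher number from compound 1 to compound 2 (0.04 log units; within the scatter). Compound 3 `O=C(Nc1ccc(Oc2ccnc3[nH]ccc23)c(F)c1)c1cn(-c2ccccc2)c2ccccc2c1=O` rests on a different core and gives 420 nM; how its core differs from that of compound 1 is not broken down here.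

Compound 4 `O=C(Nc1ccc(Oc2ccnc3[nH]ccc23)c(F)c1)c1cn(-c2ccc(F)cc2)c2ccccc2c1=O` has not yet been measured. It differs from compound 3 by fluoro in place of hydrogen on an aromatic carbon. For the measured compounds named here, this is the same kind of change as the one separating compound 1 and compound 2, but not the same: in compound 4 the fluoro enters para to a large group, whereas in compound 2 it enters ortho to a large group and meta to a bromo group. Given that the earlier change produced a 1.1-fold higher number from compound 1 to compound 2 (0.04 log units; within the scatter), little movement is expected here, though the different surroundings leave room for some. The estimated step is a 1.1-fold higher number from compound 3 to compound 4 (0.03 log units; within the scatter). Compound 4 is therefore expected to give 450 nM in this assay, with a likely range from 220 nM to 950 nM.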

Compound 4, half-maximal inhibitory concentration: 290 nM
Compound 4: the middle estimate sits 1.6-fold (0.19 log units) above what was measured; the measured number falls inside the stated range.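

In this assay, replacing phenyl with 4-fluorophenyl gave a 1.4-fold lower number from compound 3 to compound 4 (0.16 log units; within the scatter). Set beside the earlier case, the change cannot be told apart on the two cores: the same change on two cores in this assay, a 1.1-fold higher number (0.04 log units; within the scatter) from compound 1 to compound 2 and a 1.4-fold lower number (0.16 log units; within the scatter) from compound 3 to compound 4, 1.6-fold (0.20 log units) apart, within the scatter of two such steps. This shows that the change moved the number only slightly in both pairs, but it does not show that the change would behave alike on other cores, as only two pairs are shown and the fluoro is para to a large group in compound 4 but stands elsewhere in compound 2.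

The compounds shown leave open whether a different group at that same place, such as chloro, methoxy, an amine or a carboxylic acid, would move the number further than fluoro does. They also leave open how the bromo group of compound 1 would read on the core of compound 3, as no pair shown isolates that group on either core.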